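From Nitro to Benzyloxy in a Small Antiproliferative Series

The source may hold more compounds than are shown below. What is called first, only, known or untested is meant among the compounds shown, and "the series" means these compounds.

In a functional assay on KB cells (Homo sapiens) for antiproliferative activity, read by MTT assay, with a stated time of 72 h (on this read-out lower numbers stand for stronger inhibition and higher numbers for weaker inhibition), compound 1 `COc1ccc(-c2sc(C(=O)O)cc2-c2cc(OC)c(OC)c(OC)c2)cc1` gives 10400 nM. Compound 2 `COc1ccc(-c2sc(C(=O)O)cc2-c2cc(OC)c(OC)c(OC)c2)cc1[N+](=O)[O-]` gives 35900 nM, the higher of the two numbers. Compound 3 `COc1ccc(-c2sc(C(=O)O)cc2-c2cc(OC)c(OC)c(OC)c2)cc1OCc1ccccc1` differs from it as follows: benzyloxy in place of nitro on an aromatic carbon. Among the compounds with values here, only one measured step bears on this change: a 3.5-fold higher number from compound 1 to compound 2 (0.54 log units; beyond the scatter), seen when nitro replaced hydrogen. Within the data shown here, no benzyloxy compound has a measured value yet, so only a modest step towards a lower number is expected in this assay. For compound 3 the expected step is a 2.4-fold lower number from compound 2 to compound 3 (0.38 log units; beyond the scatter). For compound 3 the estimated value is 15000 nM, within a range of 5000 nM to 45000 nM.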

Compound 3, half-maximal inhibitory concentration: > 100000 nM
Compound 3: no number, only a limit; the forecaster's own chance of this, stated with the estimate: 10%; middle value at least 6.6-fold (0.82 log units) from the limit.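

Compound 3 carries no number in this assay, only a limit of the assay: the limit of > 100000 nM in this assay, at which 1 of the 3 values shown sits. Benzyloxy, ortho to a methoxy group, therefore does not reverse the loss seen with nitro: replacing nitro gives an at least 2.7-fold higher number from compound 2 to compound 3 (0.44 log units; beyond the scatter). Measured against hydrogen, the same position gives an at least 9.6-fold higher number from compound 1 to compound 3 (0.98 log units; beyond the scatter), so among these three compounds hydrogen gives the lowest number and both added groups give higher ones.

Going by these compounds, whether an amine or a hydroxyl group here would hold the number of compound 1 or lower it remains open. These compounds also cannot separate the size of the group from its other features.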